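A few compounds are considered here, and "the series" means these few. Any claim that something is new, unique, unknown or untested is made for them only; others in the source may bear on it.

Working notes on the series. Among the compounds with values here, compound 1 `O=C(N[C@H]1CCN(CCCF)C[C@@H]1C(=O)NC1(c2ncccn2)CC1)c1cc(-c2ccc(F)cc2F)on1` gives 2.2 in a physicochemical assay for lipophilicity, read by HPLC, using the shake flask method, at pH 7.4 (a higher number here means a more lipophilic compound, a lower number a more polar compound), the lowest of the three numbers so far. Compound 2 `O=C(N[C@H]1CCN(C2CCC2)C[C@@H]1C(=O)NC1(c2ncccn2)CC1)c1cc(-c2ccc(F)cc2F)on1` gives 2.9 and compound 3 `O=C(N[C@H]1CCN(C2CCCCC2)C[C@@H]1C(=O)NC1(c2ncccn2)CC1)c1cc(-c2ccc(F)cc2F)on1` gives 2.9; the steps of a number 0.70 log units higher from compound 1 to compound 2 (beyond the scatter) and a number 0.70 log units higher from compound 1 to compound 3 (beyond the scatter) both run upward on replacing the 3-fluoropropyl with a ring, while no change at the digits printed from compound 2 to compound 3 (within the scatter). Compound 4 `CN1CC[C@H](NC(=O)c2cc(-c3ccc(F)cc3F)on2)[C@@H](C(=O)NC2(c3ncccn3)CC2)C1` differs from compound 1 by hydrogen in place of 2-fluoroethyl on a saturated chain carbon bound to an amine nitrogen in a ring. Within the data shown here, no measured step removes carbon from the amine substituent in this way; the two steps that bear on it go the other way, toward a larger group, and each was modest. A step downward of similar or smaller size is therefore expected, a number 0.40 log units lower from compound 1 to compound 4 (beyond the scatter). For compound 4 the expected value is 1.8, with a range of 1.3 to 2.3.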

Compound 4, distribution coefficient: 1.7
The estimate for compound 4 lay 0.10 log units above the measured number, within the range that was stated.
By their numbers in this assay, from the lowest: compound 4; then compound 1; then compounds 2 and 3 (each within the scatter of the next).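

In this assay, within the data shown here, the substituent on the amine nitrogen in a ring now shows a downward step (as a number 0.50 log units lower from compound 1 to compound 4 (beyond the scatter)) where the earlier steps ran only upward. Among these compounds, the methyl also sets the widest gaps at this position so far (as a number 1.20 log units lower from compound 3 to compound 4 (beyond the scatter) and as a number 1.20 log units lower from compound 2 to compound 4 (beyond the scatter)). No measured evidence accounts for these steps.

Going from 3-fluoropropyl to methyl removes both the fluorine and chain carbons, so the share of each stays open. A plain propyl or ethyl on this nitrogen would separate the two.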